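The source may report more compounds than this note shows. Statements on the series, on what has been measured and on what is new or still open speak of the compounds shown alone.

Working notes on the series, values in an ADME assay on cells (Macrophage) for cytotoxicity, read by resazurin assay, with a stated time of 48 h; a higher number here means that more compound is tolerated, a lower number that less compound is tolerated:

- compound 1 `COc1ccc(-c2cc(-c3ccc(OCc4cn(Cc5ccccc5)nn4)cc3O)nc(N)n2)cc1`: 42700 nM
- compound 2 `CCCCCCn1cc(COc2ccc(-c3cc(-c4ccc(OC)cc4)nc(N)n3)c(O)c2)nn1`: "not determined" (no result reported)
- compound 3 `O=C1CC(c2ccc(Cl)cc2)Oc2cc(OCc3cn(Cc4ccccc4)nn3)ccc21`: "not determined" (no result reported)

Compound 2 has no single number in this assay: its entry reads "not determined" (no result reported). The entry for compound 3 is no different, at "not determined" (no result reported). Among the measured compounds shown here, compound 1, at 42700 nM, therefore carries the only number so far, so the series cannot be ranked and no step between measured compounds is available.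

Next in line is compound 4 `CCCCCCn1cc(COc2ccc(-c3cc(-c4ccc(Cl)cc4)nc(N)n3)c(O)c2)nn1`, which has not yet been measured. The structural change is chloro in place of methoxy on an aromatic carbon. In words, this is 4-methoxyphenyl to 4-chlorophenyl, with chloro in place of methoxy on an aromatic carbon, para to a large group.

For the measured compounds named here, no measured pair shows what this exchange does in this assay, and without a number for compound 2 the step itself cannot be read off. The working expectation is therefore a small step at most, not clearly beyond the scatter, leaning towards less compound tolerated. Going by the values given here, the only numerical anchor is compound 1 at 42700 nM, and the data give little beyond that, so the range is kept wide.

For compound 4 the expected value is 25000 nM, with an estimated range from 8000 nM to 80000 nM.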

Compound 4, half-maximal cytotoxic concentration: 30300 nM
Beside the measured number, compound 4's estimate is 1.2-fold (0.08 log units) below it, and the stated range covers the measured number.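

In this assay, among the compounds shown here, compound 4 gives 30300 nM while compound 2 has no single number, so no step between compound 2 and compound 4 can be read. The compounds shown leave open what the change from 4-methoxyphenyl to 4-chlorophenyl does in this series. No supporting evidence bears on this result.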